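A few compounds are considered here, and "the series" means these few. Any claim that something is new, unique, unknown or untested is made for them only; others in the source may bear on it.

In an ADME assay on HepG2 2.2.15 cells (Homo sapiens) for cytotoxicity (a lower number here means that less compound is tolerated, a higher number that more compound is tolerated), compound 1 `CC(=O)OCCc1c(-c2ccccc2Cl)c2cc(Cl)ccc2[nH]c1=O`, which has a methyl on the ester carbonyl carbon, gives 27000 nM. Compound 2 `COc1ccccc1/C=C/C(=O)OCCc1c(-c2ccccc2Cl)c2cc(Cl)ccc2[nH]c1=O` carries 2-(2-methoxyphenyl)ethenyl in place of that methyl and gives 770000 nM, which is a 29-fold higher number from compound 1 to compound 2 (1.46 log units; beyond the scatter). Compound 3 `COc1ccc(/C=C/C(=O)OCCc2c(-c3ccccc3Cl)c3cc(Cl)ccc3[nH]c2=O)cc1` carries 2-(4-methoxyphenyl)ethenyl at the same place. In this assay, compound 3 yields only a limit, > 1200000 nM, and not a number. Its comparison with the first ester reads an at least 44-fold higher number from compound 1 to compound 3 (1.64 log units; beyond the scatter), and its comparison with its methoxy isomer reads an at least 1.5-fold higher number from compound 2 to compound 3 (0.19 log units; that floor lies within the scatter).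

Compound 4 `O=C(/C=C/c1ccc(C(F)(F)F)cc1)OCCc1c(-c2ccccc2Cl)c2cc(Cl)ccc2[nH]c1=O` has not yet been measured. It differs from compound 3 as follows: trifluoromethyl in place of methoxy on an aromatic carbon. That is, trifluoromethyl stands in place of methoxy on an aromatic carbon, para to a large group. Among the measured compounds shown here, no measured step makes this exchange. The large steps came with the arrival of the substituted ethenyl chain, which compound 4 keeps, while moving the methoxy in compound 3 gave an at least 1.5-fold higher number from compound 2 to compound 3 (0.19 log units; that floor lies within the scatter). A value near compound 2 and well clear of compound 1 therefore seems likely, with another limit possible. The estimated step is an at least 1.7-fold lower number from compound 3 to compound 4 (0.23 log units; that floor lies within the scatter), a modest one towards a lower number. For compound 4 the expected value in this assay is 700000 nM, with an estimated range from 200000 nM to 1500000 nM.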

Compound 4, half-maximal cytotoxic concentration: > 1400000 nM
Compound 4: only a limit was reported (the forecaster's own chance of this, stated with the estimate: 35%); middle value at least 2.0-fold (0.30 log units) away from the limit.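

In this assay compound 4 gives only a limit, as compound 3 does, so the step between these two compounds cannot be read and the exchange of methoxy for trifluoromethyl on this aromatic carbon, para to a large group, has no measurable size: the limit of > 1400000 nM in this assay, at which 1 of the 4 values shown sits.

What the result does add is that the large step away from the methyl ester is still there with a second kind of group at this place, for the 2-(4-(trifluoromethyl)phenyl)ethenyl chain gives an at least 51-fold higher number from compound 1 to compound 4 (1.71 log units; beyond the scatter) and so joins the two methoxy esters. Against the isomer with methoxy on the other ring position the reading is an at least 1.8-fold higher number from compound 2 to compound 4 (0.25 log units; that floor lies within the scatter) and no order can be claimed for that pair, since the floor of this step does not clear the usual scatter.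

As far as these compounds go, whether compound 3 and compound 4 truly differ stays open, as both values are limits. Also open, from the compounds shown here alone, is whether an amine or a carboxylic acid at this aromatic carbon would keep the number this high, or bring it back towards that of compound 1.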